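The compounds below may be only part of what the source reports. "The series", "measured", "known", "first", "only" and "open" are said of these compounds alone.

Compound 2, drawn as `O=C(NO)c1ccc(NCc2nc(-c3ccsc3)nn2-c2ccccc2)cc1`, stands at the lower of the two numbers measured in an assay on Sf9 cells for inhibition of protein deacetylase HDAC6 (Homo sapiens), read by fluorescence, with a stated time of 40 min, tested at 100 nM (on this read-out lower numbers stand for less inhibition and higher numbers for more inhibition at the one concentration tested (going by the name of the read-out)), where compound 2 gives 53.4%. Its nearest neighbour is compound 1, `O=C(NO)c1ccc(NCc2nc(-c3ccc(Br)o3)nn2-c2ccccc2)cc1`, which in this assay gives 55.8%; the step of a number 2.4 percentage points lower from compound 1 to compound 2 (within the scatter) lies within the scatter of the measurement. Compound 3, `O=C(NO)c1ccc(NCc2nc(-c3ccccc3Cl)nn2-c2ccccc2)cc1`, has not yet been measured in this assay. It differs from compound 2 in one place: 2-chlorophenyl in place of thiophen-3-yl on an aromatic carbon. Among the compounds with values here, the one measured step that bears on this change is the exchange of the aryl group at the same aromatic carbon, a number 2.4 percentage points lower from compound 1 to compound 2 (within the scatter), which did not move the read-out beyond the scatter. On that single step, the exchange to 2-chlorophenyl is expected to change the number little, so the estimated step of a number 0.4 percentage points lower from compound 2 to compound 3 (within the scatter) is not expected to exceed the scatter. Compound 3 is therefore estimated at 53% in this assay, with a range from 35% to 70%.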

Compound 3, a percentage reported as inhibition, at one concentration (the size of the read-out at that concentration, not a potency): 75%
Compound 3: the middle estimate sits 22 percentage points below what was measured; the measured number lies above the stated range.
By their numbers in this assay, from the lowest: compounds 2 and 1 (each within the scatter of the next); then compound 3.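

Unlike the exchange between the two five-membered aromatic rings, the change to 2-chlorophenyl shows a number 21.6 percentage points higher from compound 2 to compound 3 (beyond the scatter) and a number 19.2 percentage points higher from compound 1 to compound 3 (beyond the scatter) in this assay and so shows that this position, on the aromatic carbon between two ring nitrogen atoms, can move the read-out. Among the three compounds, the six-membered aromatic ring bearing chlorine stands apart from both five-membered aromatic rings, which remain within the scatter of each other. Nothing given here accounts for this rise.

The compounds shown leave open whether the rise goes with the chlorine or with the six-membered ring itself, a question that a plain phenyl group could separate. They also do not tell how a group of another kind at this carbon, such as an aminomethyl group or a carboxylic acid, would read.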